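The source may report more compounds than this note shows. Statements on the series, on what has been measured and on what is new or still open speak of the compounds shown alone.

Measured so far:
compound 1 `N#Cc1ccccc1COc1ccc(-c2cc(CN3CCN(Cc4ccc(C(F)(F)F)cc4)CC3)no2)cc1`: 4000 nM
compound 2 `COc1cccc(COc2ccc(-c3cc(CN4CCN(Cc5ccc(C(F)(F)F)cc5)CC4)no3)cc2)c1`: 2000 nM

In a functional assay on MCF7 cells (Homo sapiens) for antiproliferative activity, read by sulforhodamine B assay, with a stated time of 72 h (on this read-out lower numbers stand for stronger inhibition and higher numbers for weaker inhibition), compound 2 gives 2000 nM and compound 1 gives 4000 nM. For the measured compounds named here, the only measured step in this assay, a 2.0-fold lower number from compound 1 to compound 2 (0.30 log units; within the scatter), lies within the scatter, so the two numbers cannot be separated; compound 2 simply carries the lower figure of the pair.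

Compound 3 `COc1cc(COc2ccc(-c3cc(CN4CCN(Cc5ccc(C(F)(F)F)cc5)CC4)no3)cc2)cc(OC)c1OC` differs from compound 2 by 3,4,5-trimethoxyphenyl in place of 3-methoxyphenyl on a saturated chain carbon bound to an oxygen on an aromatic ring. Going by the values given here, the one step that touches the same place, a 2.0-fold lower number from compound 1 to compound 2 (0.30 log units; within the scatter), exchanged the whole aryl group and stayed within the scatter. Among the compounds with values here, no measured pair shows what two added methoxy groups on that ring do, so the expectation rests on that single flat step alone.

Accordingly, the step from compound 2 to compound 3 is expected to stay within the scatter, a 1.3-fold lower number from compound 2 to compound 3 (0.12 log units; within the scatter). Compound 3 is estimated at 1500 nM, with a range from 400 nM to 6000 nM.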

Compound 3, half-maximal inhibitory concentration: 1800 nM
Compound 3: middle estimate off by 1.2-fold (0.08 log units), on the low side, and the stated range covers the measured number.
By their numbers in this assay, from the lowest: compounds 3, 2 and 1 (each within the scatter of the next, the first and the last beyond it).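

In this assay the larger 3,4,5-trimethoxyphenyl, with 12 heavy atoms against 8 in 3-methoxyphenyl, is accommodated on the saturated chain carbon bound to an oxygen on an aromatic ring without a separable shift (a 1.1-fold lower number from compound 2 to compound 3 (0.05 log units; within the scatter)). For the compounds shown here, the same place also gives the first step beyond the scatter (a 2.2-fold lower number from compound 1 to compound 3 (0.35 log units; beyond the scatter)), although this step is modest and compound 2 cannot be separated from either of the other two compounds. No evidence is available to explain these numbers.

Going by these compounds, the separate contribution of each added methoxy group remains open. Also open is whether an amine or a carboxylic acid on this aryl ring, or a longer chain at this place, would move the read-out further than the aryl exchanges shown here.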